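Configuration changes across one series and metabolic stability

This account rests on a few compounds, and the source may have more. Where it says the series, first, only, none or still open, it means among the compounds named here.

Measured so far:
Compound 1 `C[C@@H]1CN([C@@H](C)CO)C(=O)c2cccc(NC(=O)c3ccncc3)c2O[C@H]1CN(C)Cc1ccc(Oc2ccccc2)cc1` in an ADME assay on microsomes (Mus musculus) for metabolic stability, with a stated time of 1 h, tested at 1 uM (on this read-out higher numbers stand for a more stable compound and lower numbers for a less stable compound), gives 2%.
Compound 2 `C[C@H]1CN([C@@H](C)CO)C(=O)c2cccc(NC(=O)c3ccncc3)c2O[C@H]1CN(C)Cc1ccc(Oc2ccccc2)cc1` in this assay gives < 1%, which is a limit of the assay and not a number.
Compound 3 `C[C@@H]1CN([C@H](C)CO)C(=O)c2cccc(NC(=O)c3ccncc3)c2O[C@@H]1CN(C)Cc1ccc(Oc2ccccc2)cc1` in this assay gives < 1%, again a limit and not a number.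

Compound 3 thus stands at the floor of what this assay reports, and it shares that floor with one other value of the three shown (the limit of < 1% in this assay, at which 2 of the 3 values shown sit). Compound 4 `C[C@H](CO)N1C[C@H](C)[C@H](CN(C)Cc2ccc(Oc3ccccc3)cc2)Oc2c(NC(=O)c3ccncc3)cccc2C1=O` is the next member; its relation to compound 3 is the two compounds have the same atoms and bonds and differ only in configuration as drawn: 2 of 3 stereo elements differ; a stereocentre at a saturated ring carbon is drawn R in compound 3 and S in compound 4; a stereocentre at a saturated ring carbon is drawn S in compound 3 and R in compound 4.

For the measured compounds named here, the steps that bear on this are all changes of configuration alone. From compound 1 to compound 2 the step is a number at least 1 percentage points lower from compound 1 to compound 2 (that floor lies within the scatter) (the fact that compounds 1 and 2 differ only in the configuration as drawn), from compound 1 to compound 3 it is a number at least 1 percentage points lower from compound 1 to compound 3 (that floor lies within the scatter) (the fact that compounds 1 and 3 differ only in the configuration as drawn), and from compound 2 to compound 3 it is a step that the two limits leave unreadable from compound 2 to compound 3 (the fact that compounds 2 and 3 differ only in the configuration as drawn). Every configuration shown so far leaves the compound near or at the floor, and no step beyond the scatter has appeared among them. Inverting two ring stereocentres is therefore expected to move the read-out by a number at least 1 percentage points higher from compound 3 to compound 4 (that floor lies within the scatter) at most, that is, by nothing beyond the scatter, though a value at the limit would not be surprising. Compound 4 is estimated at 2%, within 0% to 8%.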

Compound 4, percent of the compound remaining in the Mus musculus assay: < 1%
Compound 4: no number, only a limit; the forecaster's own chance of this, stated with the estimate: 40%; at least 1 percentage points between middle value and limit.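

For the compounds shown here, in the Mus musculus assay the one readable new step is a number at least 1 percentage points lower from compound 1 to compound 4 (that floor lies within the scatter), and the steps from compound 2 and from compound 3 to compound 4 cannot be read, as both ends are limits. The pair compound 2 and compound 4 adds a change at the saturated chain carbon alone, and it too stays at the floor with no readable step: the fact that compounds 2 and 4 differ only in the configuration as drawn. In a physicochemical assay for solubility, in phosphate buffer (a higher number here means a more soluble compound, a lower number a less soluble compound), compound 3 gives 86000 nM and compound 4 gives 98000 nM with a 1.1-fold higher number from compound 3 to compound 4 (0.06 log units; within the scatter) as the step, so inverting these two ring stereocentres leaves this read-out unchanged.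

On these data alone, how far compound 2, compound 3 and compound 4 lie beneath the limit in the Mus musculus assay stays open, so they cannot be ranked. Also open, as far as these compounds go, is whether any of these configurations would read clear of the floor with a carboxylic acid in place of the side-chain hydroxyl.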